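The source may hold more compounds than are shown below. What is called first, only, known or untested is meant among the compounds shown, and "the series" means these compounds.

Working notes on the series, measured in a functional assay on RS4-11 cells (Homo sapiens) for cytotoxicity, read by MTT assay, with a stated time of 72 h; a lower number here means a stronger inhibitor, a higher number a weaker inhibitor.

Compound 1 `CC1=C[C@H](OC(=O)c2ccc(O)cc2)[C@@H]2[C@](C)(CC[C@@]2(O)C(C)C)CC1=O` gives 28200 nM in this assay. Compound 3 `CC1=CC[C@]2(C)[C@@H]([C@@H](OC(=O)c3ccc(O)cc3)C1)[C@](O)(C(C)C)C[C@@H]2O` gives 33400 nM in this assay; the two values lie within the scatter of each other, so no order is read between compound 1 and compound 3. Compound 2 `C/C=C(\C)C(=O)O[C@H]1C[C@@]2(C)O[C@H]2[C@@H](OC(C)=O)[C@@]2(C)CC[C@@](O)(C(C)C)[C@H]12` reaches only a limit of the assay, > 100000 nM. Going by the values given here, that limit, (the limit of > 100000 nM in this assay, at which 1 of the 3 values shown sits), gives no number for compound 2, and no step is worked out from it. Among the two numbers, compound 1 holds the lowest, with compound 3 nearest.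

Compound 4 `COc1ccc(C(=O)O[C@H]2C=C(C)C(=O)C[C@@]3(C)CC[C@@](O)(C(C)C)[C@H]23)cc1` is the next structure to be measured. It differs from compound 1 as follows: methyl in place of hydrogen on an oxygen on an aromatic ring. The change is small, one carbon on the oxygen on the aromatic ring, turning 4-hydroxyphenyl into 4-methoxyphenyl, with no donor or acceptor gained. Among the compounds with values here, no measured pair carries this change, so the step is not checked by any neighbour.

The step from compound 1 to compound 4 is expected to be small, at most a modest weakening and likely none beyond the scatter, estimated as a 1.3-fold higher number from compound 1 to compound 4 (0.13 log units; within the scatter). Compound 4 is therefore estimated at 38000 nM in this assay, with a range from 12000 nM to 100000 nM.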

Compound 4, half-maximal inhibitory concentration: 28600 nM
The estimate for compound 4 lay 1.3-fold (0.12 log units) above the measured number, within the range that was stated.
By their numbers in this assay, from the lowest: compounds 1, 4 and 3 (each within the scatter of the next). At a limit, above all of these: compound 2.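

In this assay, going by these compounds alone, replacing hydroxy with methoxy on the aromatic ring gives a 1.0-fold higher number from compound 1 to compound 4 (0.01 log units; within the scatter), the first step that can be read at this position. Within the data shown here, the hydrogen on that oxygen can therefore carry a methyl on the core of compound 1 without a measurable shift in this assay, so the free hydroxy of the 4-hydroxyphenyl group is not required to hold the number at this level, and the earlier compounds, with no pair varying here, could not show this. Among these compounds, the step gives a size only, and nothing measured so far bears on why it is so small.

From the compounds shown here alone, the finding rests on a single pair, so it is open whether the same replacement would read alike on the core of compound 3, which also carries the 4-hydroxyphenyl group. Also open, going by these compounds, is how much more this oxygen accepts, for instance a longer chain such as butoxy, a carboxylic acid at the end of such a chain, or an amine in place of the oxygen.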